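Hydroxy on the benzyl group of compound 2

A few compounds are considered here, and "the series" means these few. Any claim that something is new, unique, unknown or untested is made for them only; others in the source may bear on it.

Values in an ADME assay on J774.1 cells (Mus musculus) for cytotoxicity, read by resazurin assay, with a stated time of 48 h; a lower number here means a stronger inhibitor, a higher number a weaker inhibitor:
compound 1 `CCCCn1cc(C(=O)O)c(=O)c2cc(F)c(N3CCC(C(N)=O)CC3)cc21`: > 100000 nM
compound 2 `CCCCn1cc(C(=O)NCc2ccccc2)c(=O)c2cc(F)c(N3CCC(C(N)=O)CC3)cc21`: 47000 nM

The entry for compound 1 of > 100000 nM is a limit of the assay. For the measured compounds named here, compound 2, at 47000 nM, therefore holds the only actual number so far.

Compound 3 `CCCCn1cc(C(=O)NCc2ccc(O)cc2)c(=O)c2cc(F)c(N3CCC(C(N)=O)CC3)cc21` carries a single change hydroxy in place of hydrogen on an aromatic carbon, which turns benzyl to 4-hydroxybenzyl.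

Going by the values given here, only one measured step bears on this, and only indirectly: an at least 2.1-fold lower number from compound 1 to compound 2 (0.32 log units; beyond the scatter). That step, beyond the scatter, introduced the benzylamino group itself, whereas the new change sits further out on that group. No substituent on its aromatic ring has been measured yet. Little movement is therefore expected in this assay, perhaps towards a slightly higher number, and possibly none beyond the scatter. The expected change is a 1.3-fold higher number from compound 2 to compound 3 (0.11 log units; within the scatter). Compound 3 is expected at 60000 nM, with an estimated range of 28000 nM to 100000 nM.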

Compound 3, half-maximal inhibitory concentration: 41600 nM
Estimate against measurement, compound 3: 1.4-fold (0.16 log units) above, within the range that was stated.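

In this assay, hydroxy as the first substituent on the benzyl ring gives a 1.1-fold lower number from compound 2 to compound 3 (0.05 log units; within the scatter), so the ring takes this group here without a shift beyond the scatter. With (4-hydroxybenzyl)amino on the carbonyl carbon, the separation from the carboxylic acid also persists, at an at least 2.4-fold lower number from compound 1 to compound 3 (0.38 log units; beyond the scatter). The value of compound 1 is a limit, so that step gives a bound and not a size: the limit of > 100000 nM in this assay, at which 1 of the 3 values shown sits.

A single substituent at a single ring position leaves open whether methoxy, fluoro or an amine would read the same, on that carbon or on another carbon of the ring. Also open, from the compounds shown here alone, is whether a longer chain between the amide nitrogen and the ring would move the number in this assay.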